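Demethylation on the hydroxyethyl side chain of a curcuminoid

The compounds below may be only part of what the source reports. "The series", "measured", "known", "first", "only" and "open" are said of these compounds alone.

Three curcumin-like compounds were examined in a toxicity assay on CHO-K1 cells (Cricetulus griseus) for cytotoxicity, read by MTT assay, with a stated time of 48 h; on this read-out lower numbers stand for stronger inhibition and higher numbers for weaker inhibition. Compound 1 `COc1cc(/C=C/C(=O)/C=C(/C=C/c2ccc(O)c(OC)c2)NCCO)ccc1O` gives 87500 nM. Compound 2 `COCCNC(=C\C(=O)/C=C/c1ccc(O)cc1)/C=C/c1ccc(O)cc1` gives 34900 nM. Compound 3 `COCCNC(=C\C(=O)/C=C/c1ccc(O)c(OC)c1)/C=C/c1ccc(O)c(OC)c1` gives 63000 nM. The value of compound 2 lies within the usual scatter of that of compound 3, so no order between these two can be drawn; the gap from compound 2 to compound 1 is beyond the scatter.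

Compound 3 and compound 1 differ in one place: hydrogen in place of methyl on an oxygen on a saturated carbon. This change produced a 1.4-fold higher number from compound 3 to compound 1 (0.14 log units; within the scatter), a step within the scatter.

Compound 4 `O=C(/C=C(/C=C/c1ccc(O)cc1)NCCO)/C=C/c1ccc(O)cc1` has not yet been measured. It is related to compound 2 by the same change: hydrogen in place of methyl on an oxygen on a saturated carbon. The place of the change is described in the same words for both pairs. The difference between the cores of compound 2 and compound 3 is not broken down here.

On the strength of the earlier step, compound 4 is expected to show a 1.3-fold higher number from compound 2 to compound 4 (0.11 log units; within the scatter), a step of similar size and within the scatter. The estimate for compound 4 in this assay is therefore 45000 nM, with a likely range from 20000 nM to 100000 nM.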

Compound 4, half-maximal inhibitory concentration in the CHO-K1 assay: 66000 nM
Beside the measured number, compound 4's estimate is 1.5-fold (0.17 log units) below it; the measured number falls inside the stated range.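

In the CHO-K1 assay compound 2 gives 34900 nM and compound 4 gives 66000 nM. For the compounds shown here, in the CHO-K1 assay replacing methyl with hydrogen on the second core gave a 1.9-fold higher number from compound 2 to compound 4 (0.28 log units; within the scatter), and this step agrees with the one seen on the first core: the same change on two cores in the CHO-K1 assay, a 1.4-fold higher number (0.14 log units; within the scatter) from compound 3 to compound 1 and a 1.9-fold higher number (0.28 log units; within the scatter) from compound 2 to compound 4, 1.4-fold (0.13 log units) apart, within the scatter of two such steps On these two cores, then, the change from 2-methoxyethyl to 2-hydroxyethyl carried over without a difference that can be told apart, but each step alone also lies within the scatter, so this shows only that neither core gave a clear shift, not that the change moves the number by a fixed amount. In a physicochemical assay for solubility, using the shake flask method, in phosphate buffer, with a stated time of 90 min, at pH 6.8 (on this read-out higher numbers stand for higher solubility and lower numbers for lower solubility), compound 2 gives 37500 nM and compound 4 gives 38700 nM. In the physicochemical assay the same change gave a 1.0-fold higher number from compound 2 to compound 4 (0.01 log units; within the scatter), and two cores are too few to say how it would behave on a third.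

All four compounds carry either the 2-methoxyethyl or the 2-hydroxyethyl chain, and the steps between them stay within the scatter. Going by these compounds, what remains open is whether an amine, a carboxylic acid or a longer chain in its place would give a step beyond the scatter.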